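The compounds below may be only part of what the source reports. "The series", "measured", "known", "first", "only" and "open" are said of these compounds alone.

Compound 1 `CCCC(=O)c1ccc(OCCCCOc2cc(C(=O)O)ccc2OC)c(C)c1O` is the reference point for this step. Among the measured compounds shown here, in an assay on HEK293 cells for positive allosteric modulation of metabotropic glutamate receptor 2 (Rattus norvegicus), read by thallium flux, with a stated time of 2.5 min (on this read-out lower numbers stand for smaller maximal responses and higher numbers for larger maximal responses), compound 1 gives 82.8%, the lower of the two numbers measured so far. Compound 2 `Cc1c(OCCCCOc2ccc(F)c(C(=O)O)c2)ccc(C(=O)CC(C)(C)C)c1O` gives 94.6% in this assay, a number that lies above compound 1 by more than the usual scatter; the two structures differ in several places at once, so no single step can be read from them, and the values stand only as two points.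

Compound 3 `COc1ccc(C(=O)O)cc1OCCCCOc1ccc(C(C)=O)c(O)c1C` has not yet been measured in this assay. Set against compound 1, it differs in one place: hydrogen in place of ethyl on a saturated chain carbon bound to a carbonyl carbon. For the measured compounds named here, nothing measured so far isolates this change, so the direction rests on the shortening of the propylcarbonyl to acetyl alone. The maximal response is expected to stay close to that of compound 1 or to fall slightly, a step of a number 6.8 percentage points lower from compound 1 to compound 3 (within the scatter) being estimated, not clearly beyond the scatter. Compound 3 is therefore estimated to give 76% in this assay, with a range from 60% to 92%.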

Compound 3, largest response reached (reported as percent of maximum), in percent of the reference or control that the assay uses: 70.7%
Compound 3: middle estimate off by 5.3 percentage points, on the high side; the range from low to high includes it.
By their numbers in this assay, from the lowest: compound 3; then compound 1; then compound 2.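

In this assay, the series now has its first step that can be read from a single change: hydrogen in place of ethyl on a saturated chain carbon bound to a carbonyl carbon gives a number 12.1 percentage points lower from compound 1 to compound 3 (beyond the scatter). The change from propylcarbonyl to acetyl can thus be judged on its own, which the earlier pair of compounds did not allow, and it shows that the maximal response depends on what this carbon carries, with acetyl on the lower side by a modest step that still lies beyond the usual scatter. Nothing at hand bears on why the response moves with this change.

This is one step between two compounds, so it gives a direction for this pair but no trend with chain length. Open, as far as these compounds go, are where an ethylcarbonyl would fall relative to compound 3 and compound 1, whether a longer chain such as butylcarbonyl would raise the response further or lose it, and whether the same step would hold on a core carrying other substituents.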